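Swapping the Tail Amine of Compound 2

A few compounds are considered here, and "the series" means these few. Any claim that something is new, unique, unknown or untested is made for them only; others in the source may bear on it.

In a functional assay on HT-29 cells (Homo sapiens) for cytotoxicity, read by MTT assay, with a stated time of 72 h (on this read-out higher numbers stand for weaker inhibition and lower numbers for stronger inhibition), compound 2 `COc1cc2c(Oc3ccc(NC(=O)c4nccc(-c5ccc(F)cc5)n4)cc3F)ccnc2cc1OCCCN1CCCCC1` gives 120 nM, the lowest of the three numbers recorded. Compound 1 `COc1cc2c(Oc3ccc(NC(=O)c4nccc(-c5ccc(C)cc5)n4)cc3F)ccnc2cc1OCCCN1CCCCC1` gives 620 nM, and compound 3 `COc1cc2c(Oc3ccc(NC(=O)c4nccc(-c5ccc(F)cc5F)n4)cc3F)ccnc2cc1OCCCN1CCCCC1` gives 400 nM. Both comparisons against compound 2 lie beyond the scatter: a 5.2-fold lower number from compound 1 to compound 2 (0.71 log units; beyond the scatter) and a 3.3-fold higher number from compound 2 to compound 3 (0.52 log units; beyond the scatter), while a 1.6-fold lower number from compound 1 to compound 3 (0.19 log units; within the scatter). All three measured steps concern fluoro and methyl groups on an aromatic carbon, and none touches the amine at the end of the chain.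

Compound 4 `COc1cc2c(Oc3ccc(NC(=O)c4nccc(-c5ccc(F)cc5)n4)cc3F)ccnc2cc1OCCCN1CCN(C)CC1` differs from compound 2 only there: 4-methylpiperazin-1-yl in place of piperidin-1-yl on a saturated chain carbon, three bonds along the chain from an oxygen on an aromatic ring. Among the compounds with values here, no measured step bears on this change, so the measured numbers give no direction for it; everything that separates compound 2 from compounds 1 and 3 is kept unchanged in compound 4. Compound 4 is therefore expected to sit close to compound 2 in this assay, with an expected step of no change at the digits printed from compound 2 to compound 4 (within the scatter) and nothing beyond the scatter. The estimate for compound 4 is 120 nM, with an expected range from 50 nM to 300 nM.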

Compound 4, half-maximal inhibitory concentration: 42 nM
For compound 4 the middle estimate is 2.9-fold (0.46 log units) above the measured one, and the stated range ends above it.
By their numbers in this assay, from the lowest: compound 4; then compound 2; then compounds 3 and 1 (each within the scatter of the next).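

In this assay, putting 4-methylpiperazin-1-yl in place of piperidin-1-yl on a saturated chain carbon, three bonds along the chain from an oxygen on an aromatic ring, gives a 2.9-fold lower number from compound 2 to compound 4 (0.46 log units; beyond the scatter), so the amine at the end of the chain can move this read-out beyond the scatter while the rest of the structure stays fixed. Compounds 1, 2 and 3 all carry piperidin-1-yl and differ only in the fluoro and methyl groups on an aromatic carbon, so they could say nothing about this position, and the lowest number no longer belongs to compound 2 but to compound 4. No measurement at hand accounts for why the entering group lowers the number.

The compounds shown leave open whether piperazin-1-yl without the methyl, or morpholin-4-yl, would behave like 4-methylpiperazin-1-yl on the same chain, and whether the step survives on a shorter 2-(4-methylpiperazin-1-yl)ethyl chain. They also leave open whether the same amine swap would lower the number when paired with the 4-methylphenyl of compound 1 or the 2,4-difluorophenyl of compound 3.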